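This account rests on a few compounds, and the source may have more. Where it says the series, first, only, none or still open, it means among the compounds named here.

Measured in an assay on isolated protein for inhibition of Rho-associated protein kinase 2 (Homo sapiens), read by radiometric assay; a lower number here means a stronger inhibitor, a higher number a weaker inhibitor:
Compound 1 `NCc1ccc(C(=O)Nc2ccncc2F)cc1-c1cccc(C(=O)Oc2ccccc2)c1`: 6.2 nM
Compound 2 `NCc1ccc(C(=O)Nc2ccncc2F)cc1-c1cccc(C(=O)OCC2CC2)c1`: 2.7 nM
Compound 3 `NCc1ccc(C(=O)Nc2ccncc2)cc1-c1cccc(C(=O)OCc2ccccc2)c1`: 45 nM

Among the three measured compounds, compound 2 gives the lowest number; compound 1 stands a modest way above it, and compound 3 much further above. Compound 4 `CCCOC(=O)c1cccc(-c2cc(C(=O)Nc3ccncc3F)ccc2CN)c1` differs from compound 2 by ethyl in place of cyclopropyl on a saturated chain carbon bound to an oxygen next to a carbonyl group. Within the data shown here, one measured step touches the same part of the structure: a 2.3-fold lower number from compound 1 to compound 2 (0.36 log units; beyond the scatter), a change at the oxygen of the same ester. The change from compound 2 to compound 4 is a smaller one, a three-membered ring giving way to a short chain, so no step beyond the scatter is expected, with a slight weakening as the more likely direction. Compound 4 is therefore expected to show a 1.3-fold higher number from compound 2 to compound 4 (0.11 log units; within the scatter) in this assay, an estimate of 3.5 nM with a range from 1.5 nM to 8 nM.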

Compound 4, half-maximal inhibitory concentration: 5.1 nM
Estimate against measurement, compound 4: 1.5-fold (0.16 log units) below, and the stated range covers the measured number.
By their numbers in this assay, from the lowest: compounds 2, 4 and 1 (each within the scatter of the next, the first and the last beyond it); then compound 3.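

Swapping cyclopropyl for ethyl at this ester gives no step that can be told from the scatter (a 1.9-fold higher number from compound 2 to compound 4 (0.28 log units; within the scatter)), so the three-membered ring is not required for a low number here. Compound 4 also cannot be told apart from compound 1 (a 1.2-fold lower number from compound 1 to compound 4 (0.08 log units; within the scatter)), even though compound 1 and compound 2 differ beyond the scatter, which places the open propyl chain level with each of them. Nothing measured here explains these steps.
Still open, as far as these compounds go, is how a longer chain, or a carboxylic acid in place of this ester, would fare.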